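The source may hold more compounds than are shown below. What is called first, only, known or untested is meant among the compounds shown, and "the series" means these compounds.

Measured in a functional assay on A2780 cells (Homo sapiens) for cytotoxicity; on this read-out lower numbers stand for stronger inhibition and higher numbers for weaker inhibition:
- compound 1 `CCc1cnc(CSc2cnc(NC(C)=O)s2)o1`: 1400 nM
- compound 2 `CC(=O)Nc1ncc(SCc2ncc(C(C)C)o2)s1`: 200 nM
- compound 3 `C[C@@H](C(=O)Nc1ncc(SCc2ncc(C(C)(C)C)o2)s1)c1ccccc1`: 900 nM

Compound 3, at 900 nM, lies within the usual scatter of compound 1 at 1400 nM. Its number is clearly higher than that of compound 2 at 200 nM, so it inhibits more weakly than compound 2. Those two compounds differ in more than one place, so this gap cannot be assigned to any single group.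

The next compound is compound 4 `CC(C)(C)c1cnc(CSc2cnc(NC(=O)Nc3c(Cl)cccc3Cl)s2)o1`. The change from compound 3 is (2,6-dichlorophenyl)amino in place of 1-phenylethyl on a carbonyl carbon. In words, (2,6-dichlorophenyl)amino stands in place of 1-phenylethyl on a carbonyl carbon, and the rest of the structure stays the same.

Among the compounds with values here, only one measured step changes a single place: a 7.0-fold lower number from compound 1 to compound 2 (0.85 log units; beyond the scatter). It is modest, and it comes from methyl replacing hydrogen on a saturated chain carbon, which is a different place from the one changing now. It shows that a small edit can move the number beyond the scatter, but it gives no direction for the present swap. Within the data shown here, no measured step covers this carbonyl carbon, so no clear shift can be predicted. The estimated change is a 1.3-fold lower number from compound 3 to compound 4 (0.11 log units; within the scatter), and the uncertainty around it is wide.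

For compound 4 the expected value is 700 nM, with an estimated range of 150 nM to 3000 nM.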

Compound 4, half-maximal inhibitory concentration: 1500 nM
The estimate for compound 4 lay 2.1-fold (0.33 log units) below the measured number, and the stated range covers the measured number.
By their numbers in this assay, from the lowest: compound 2; then compounds 3, 1 and 4 (each within the scatter of the next).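

Within the data shown here, this is the first reading at the carbonyl carbon: in this assay, putting (2,6-dichlorophenyl)amino in place of 1-phenylethyl gives a 1.7-fold higher number from compound 3 to compound 4 (0.22 log units; within the scatter), a step that stays within the scatter. The swap is not a small one, since the entering group carries a nitrogen, two chlorine atoms and a hydrogen-bond donor, while the leaving group carries a defined stereocentre, yet compound 3 and compound 4 cannot be told apart on this read-out. So the one earlier step, made at a saturated chain carbon, moved the number beyond the scatter, whereas this larger exchange of atoms at the carbonyl carbon does not, and no measurement here offers any explanation for the result.

This single step cannot show whether the stereocentre, the added nitrogen and the chlorine atoms each leave the number alone or whether their separate effects merely cancel out. A plain phenylamino group without the chlorine atoms, or a carboxylic acid on the same chain, would be needed to test how far this indifference at the carbonyl carbon extends.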